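Hydrazone aryl exchange on the shared core

The source may report more compounds than this note shows. Statements on the series, on what has been measured and on what is new or still open speak of the compounds shown alone.

compound 1 `COc1ccc(/C(C)=N/Nc2nc3ccccc3nc2Cc2ccccc2)cc1`: 280000 nM
compound 2 `C/C(=N\Nc1nc2ccccc2nc1Cc1ccccc1)c1cccs1`: 850000 nM

In an assay on isolated protein for inhibition of Amine oxidase [flavin-containing] B (Homo sapiens), read by spectrophotometry (a higher number here means a weaker inhibitor, a lower number a stronger inhibitor), compound 2 gives 850000 nM, the higher of the two numbers; compound 1 gives 280000 nM. Compound 3 `C/C(=N\Nc1nc2ccccc2nc1Cc1ccccc1)c1ccc(N)cc1` differs from compound 2 by 4-aminophenyl in place of thiophen-2-yl on a carbon with a double bond to nitrogen. Among the measured compounds shown here, the one measured step bearing on this is a 3.0-fold higher number from compound 1 to compound 2 (0.48 log units; beyond the scatter), in which a six-membered aromatic ring of carbon only gave way to thiophen-2-yl. With such a ring returning, the expected step is a 2.8-fold lower number from compound 2 to compound 3 (0.45 log units; beyond the scatter), a move back toward the number of compound 1 rather than none. On that basis compound 3 is estimated at 300000 nM, with a range of 100000 nM to 1000000 nM.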

Compound 3, half-maximal inhibitory concentration: 860000 nM
Estimate against measurement, compound 3: 2.9-fold (0.46 log units) below; measured number inside the range.
By their numbers in this assay, from the lowest: compound 1; then compounds 2 and 3 (each within the scatter of the next).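

In this assay, a six-membered aromatic ring of carbon only returning on the carbon with a double bond to nitrogen does not by itself bring back the number of compound 1: 4-aminophenyl in place of thiophen-2-yl gives a 1.0-fold higher number from compound 2 to compound 3 (0.01 log units; within the scatter) and leaves the two compounds within the scatter. With that ring kept, amino in place of methoxy on an aromatic carbon gives a 3.1-fold higher number from compound 1 to compound 3 (0.49 log units; beyond the scatter) and so separates compounds that share the ring. No measurement at hand accounts for this.

Open, as far as these compounds go, is whether the lower number of compound 1 belongs to methoxy alone, or would also come with ethoxy, hydroxyl, chlorine or an unsubstituted phenyl.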